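Amide to Urea Swap: Expected Effect on Cell Growth

The compounds below may be only part of what the source reports. "The series", "measured", "known", "first", "only" and "open" are said of these compounds alone.

Measured compounds:
- compound 1 `COc1cc(-c2nn(-c3cccc(NC(=O)Nc4cc(C(F)(F)F)cc(C(F)(F)F)c4)c3)cc2-c2ccncc2)ccc1Cl`: 610 nM
- compound 2 `COc1cc(-c2nn(-c3cccc(NC(=O)c4cccc(C(F)(F)F)c4)c3)cc2-c2ccncc2)ccc1Cl`: 690 nM

In a functional assay on A498 cells (Homo sapiens) for inhibition, read by sulforhodamine B assay, with a stated time of 48 h (a higher number here means a weaker inhibitor, a lower number a stronger inhibitor), compound 1 gives 610 nM, and in this assay compound 2 gives 690 nM. Compound 2 carries the higher of the two numbers, but the gap to compound 1 is small enough to fall within the usual scatter of this assay, so the two cannot be told apart.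

Compound 3 `COc1cc(-c2nn(-c3cccc(NC(=O)Nc4cccc(C(F)(F)F)c4)c3)cc2-c2ccncc2)ccc1Cl` has not yet been measured. It differs from compound 2 in one place: (3-(trifluoromethyl)phenyl)amino in place of 3-(trifluoromethyl)phenyl on a carbonyl carbon. Going by the values given here, compound 3 thus carries a urea, as compound 1 does, but with only one trifluoromethyl group on the outer ring, as compound 2 does.

Among the compounds with values here, with no measured step between compounds of this pair, no large change is expected from compound 2 to compound 3: the estimated step is a 1.2-fold lower number from compound 2 to compound 3 (0.06 log units; within the scatter), which lies within the scatter. Compound 3 is therefore expected to give about 600 nM, with a plausible range from 250 nM to 1500 nM.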

Compound 3, half-maximal inhibitory concentration: 960 nM
For compound 3 the middle estimate is 1.6-fold (0.20 log units) below the measured one, within the range that was stated.
By their numbers in this assay, from the lowest: compounds 1, 2 and 3 (each within the scatter of the next).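

In this assay, replacing the 3-(trifluoromethyl)phenyl on the carbonyl carbon with (3-(trifluoromethyl)phenyl)amino turns the amide into a urea and adds one hydrogen-bond donor, yet it amounts only to a 1.4-fold higher number from compound 2 to compound 3 (0.14 log units; within the scatter) and does not separate the two compounds. Within the urea pair, hydrogen in place of trifluoromethyl on an aromatic carbon gives a 1.6-fold higher number from compound 1 to compound 3 (0.20 log units; within the scatter) and also leaves the two compounds indistinguishable, so neither single change has a measurable effect in this small set. No measurement available here explains these results.

The compounds shown leave open whether other groups on that aromatic carbon, such as a nitrile or an amine, would give a clearer difference. They also leave open whether a carbamate in place of the urea would do so.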